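Working notes on compound 3 of the series

This account rests on a few compounds, and the source may have more. Where it says the series, first, only, none or still open, it means among the compounds named here.

Among the compounds with values here, in a functional assay on MDA-MB-231 cells (Homo sapiens) for cytotoxicity, read by MTT assay, with a stated time of 48 h (on this read-out lower numbers stand for stronger inhibition and higher numbers for weaker inhibition), compound 2 `Cc1ccc(-c2cn(/N=C/c3cc4cc(C)ccc4nc3Cl)c(N)n2)cc1` gives 22300 nM and stands lowest of the two numbers so far. Compound 1 `Cc1ccc2nc(Cl)c(/C=N/n3cc(-c4ccccc4)nc3N)cc2c1` gives 48100 nM. Within the data shown here, the only measured step, a 2.2-fold lower number from compound 1 to compound 2 (0.33 log units; beyond the scatter), puts methyl where hydrogen stood. Compound 3 `COc1ccc(-c2cn(/N=C/c3cc4cc(C)ccc4nc3Cl)c(N)n2)cc1` differs from compound 2 by methoxy in place of methyl on an aromatic carbon. That measured step concerns a different kind of change and offers no direction for swapping one substituent for another at this carbon. Compound 3 is therefore expected to show a step of a 1.1-fold lower number from compound 2 to compound 3 (0.05 log units; within the scatter) that does not go beyond the scatter. Compound 3 is estimated at 20000 nM, within a range from 8000 nM to 50000 nM.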

Compound 3, half-maximal inhibitory concentration: 23600 nM
Compound 3: the middle estimate sits 1.2-fold (0.07 log units) below what was measured, and the stated range covers the measured number.
By their numbers in this assay, from the lowest: compounds 2 and 3 (each within the scatter of the next); then compound 1.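

In this assay the change from 4-methylphenyl to 4-methoxyphenyl gives a 1.1-fold higher number from compound 2 to compound 3 (0.02 log units; within the scatter), so at this carbon the two groups cannot be told apart, even with the hydrogen-bond acceptor counted for methoxy. Methoxy in place of hydrogen gives a 2.0-fold lower number from compound 1 to compound 3 (0.31 log units; beyond the scatter), so a second group now reads apart from hydrogen here, again by a modest step. No measured evidence on the cause of these steps is at hand.

As far as these compounds go, whether an amine or a carboxylic acid at this carbon would move the number away from compound 2 and compound 3 stays open. So does whether a longer chain, such as butoxy, would do so.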